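A few compounds are considered here, and "the series" means these few. Any claim that something is new, unique, unknown or untested is made for them only; others in the source may bear on it.

Measured so far:
Compound 1 `CC(C)=CCC/C(C)=C/COc1cc(=O)n(CCCO)c2c1CC(C/C=C(\C)CCC=C(C)C)C(C)(C)C2` — 3.1%
Compound 2 `COc1ccccc1NC(=O)Oc1cc(=O)n(CCCO)c2c1CC(C/C=C(\C)CCC=C(C)C)C(C)(C)C2` — 0%
Compound 3 `CC(C)=CCC/C(C)=C/CC1Cc2c(OC(=O)Nc3cccc(F)c3)cc(=O)n(CCCO)c2CC1(C)C` — 0%

These three compounds share one core and were tested in a functional assay on PANC-1 cells (Homo sapiens) for inhibition, read by MTT assay, with a stated time of 24 h, tested at 10 uM; a lower number here means less inhibition, a higher number more inhibition at the concentration tested (going by the name of the read-out). Compound 3 stands level with compound 2 at the digits printed, and the two are together the lowest of the three numbers; compound 1 is a number 3.1 percentage points lower from compound 1 to compound 3 (within the scatter) away, which is within the scatter, so no ordering among the three can be read from these values.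

Compound 4 `CC(C)=CCC/C(C)=C/CC1Cc2c(OC(=O)Nc3ccc(F)c(Cl)c3)cc(=O)n(CCCO)c2CC1(C)C` has not yet been measured. It differs from compound 3 in one place: 3-chloro-4-fluorophenyl in place of 3-fluorophenyl on an amide-type nitrogen. The step that bears on this is the swap of one aryl group for another on the same amide-type nitrogen, which gave no change at the digits printed from compound 2 to compound 3 (within the scatter). Among the measured compounds shown here, no step here moves beyond the scatter, so nothing in the numbers points to a change in either direction.

Compound 4 is therefore expected to give 2%, within the range 0% to 12%. The expected step is a number 2 percentage points higher from compound 3 to compound 4 (within the scatter), none beyond the scatter.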

Compound 4, a percentage reported as inhibition, at one concentration (the size of the read-out at that concentration, not a potency): 0%
The estimate for compound 4 lay 2 percentage points above the measured number, within the range that was stated.
By their numbers in this assay, from the lowest: compounds 2, 3, 4 and 1 (each within the scatter of the next).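

Going from 3-fluorophenyl to 3-chloro-4-fluorophenyl on the amide-type nitrogen gives no change at the digits printed from compound 3 to compound 4 (within the scatter) and so adds a third aryl group that the numbers cannot separate from the others, as the swap from 2-methoxyphenyl also gives no change at the digits printed from compound 2 to compound 4 (within the scatter) here. Putting (3-chloro-4-fluorophenyl)carbamoyl in place of 3,7-dimethylocta-2,6-dien-1-yl on the oxygen gives a number 3.1 percentage points lower from compound 1 to compound 4 (within the scatter) as well, so this larger change on the oxygen also stays small. Nothing measured here offers an explanation for these results.

Still open, as far as these compounds go, is whether an aryl group carrying an amine or a carboxylic acid on this nitrogen would give a number beyond the scatter. From the compounds shown here alone, a longer chain between the nitrogen and the ring remains equally open.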